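The source may hold more compounds than are shown below. What is called first, only, known or untested is meant among the compounds shown, and "the series" means these compounds.

Working notes on the series, which shares one core and varies a single group on a saturated chain carbon bound to an aromatic carbon and a saturated chain carbon. In an ADME assay on the whole organism for pharmacokinetics, with Rattus norvegicus as the target (on this read-out higher numbers stand for higher oral bioavailability and lower numbers for lower oral bioavailability), compound 1 (`COc1nc2ccc(Br)cc2cc1[C@@H](c1cc(C)c(C)s1)[C@@](O)(CCN(C)C)c1cccc(F)c1`) gives 48%, compound 2 (`COc1nc2ccc(Br)cc2cc1[C@@H](c1cncc(C)c1)[C@@](O)(CCN(C)C)c1cccc(F)c1`) gives 24% and compound 3 (`COc1nc2ccc(Br)cc2cc1[C@@H](c1ccc(N(C)C)nc1)[C@@](O)(CCN(C)C)c1cccc(F)c1`) gives 45%. Compound 3 cannot be separated from compound 1, given the step of a number 3 percentage points lower from compound 1 to compound 3 (within the scatter). Its gap to compound 2 is a real one, given the step of a number 21 percentage points higher from compound 2 to compound 3 (beyond the scatter).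

Compound 4 (`COc1cc([C@H](c2cc3cc(Br)ccc3nc2OC)[C@@](O)(CCN(C)C)c2cccc(F)c2)cnc1OC`) carries 5,6-dimethoxypyridin-3-yl in place of 6-(dimethylamino)pyridin-3-yl on a saturated chain carbon bound to an aromatic carbon and a saturated chain carbon.

All three measured steps are exchanges at this same place. Going by the values given here, the closest precedent is the step of a number 21 percentage points higher from compound 2 to compound 3 (beyond the scatter), which links the two pyridin-3-yl groups measured so far. The step of a number 24 percentage points lower from compound 1 to compound 2 (beyond the scatter) shows a similar size, while the step of a number 3 percentage points lower from compound 1 to compound 3 (within the scatter) shows that an exchange here can also leave the number unchanged within the scatter. Among the compounds with values here, no measured compound carries a methoxy group on this pyridine, so the data fix no direction firmly.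

For compound 4, the expected step is small, at a number 7 percentage points lower from compound 3 to compound 4 (within the scatter). Compound 4 is estimated at 38% in this assay, with an expected range of 20% to 54%.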

Compound 4, oral bioavailability: 36%
Estimate against measurement, compound 4: 2 percentage points above; low and high end bracket the measured number.
By their numbers in this assay, from the lowest: compound 2; then compounds 4, 3 and 1 (each within the scatter of the next, the first and the last beyond it).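

Going by these compounds alone, the step of a number 9 percentage points lower from compound 3 to compound 4 (within the scatter) in this assay leaves 5,6-dimethoxypyridin-3-yl indistinguishable from 6-(dimethylamino)pyridin-3-yl at this position, so compound 3 is no longer the only pyridin-3-yl compound that stands clear of compound 2. The step of a number 12 percentage points higher from compound 2 to compound 4 (beyond the scatter) confirms this separation for a pyridine with no dimethylamino group, whereas the step of a number 12 percentage points lower from compound 1 to compound 4 (beyond the scatter) gives the first pyridin-3-yl exchange from the 4,5-dimethylthiophen-2-yl group of compound 1 that is beyond the scatter while leaving the number above that of compound 2. The series therefore shows an intermediate compound, since compound 4 is separated from both compound 1 and compound 2 but not from compound 3, and nothing shown here gives a reason for these differences.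

The compounds shown leave open whether one methoxy group alone, as in a 6-methoxypyridin-3-yl group, would read like compound 4 or like compound 2. They also leave open how a ring amine such as morpholine in place of the dimethylamino group of compound 3, or a plain phenyl group, would sit among these numbers.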